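This account rests on a few compounds, and the source may have more. Where it says the series, first, only, none or still open, it means among the compounds named here.

In a functional assay on RS4-11 cells (Homo sapiens) for inhibition, read by CCK-8 assay, with a stated time of 72 h (a lower number here means a stronger inhibitor, a higher number a weaker inhibitor), two related compounds have been measured so far. Compound 1 (`CC1(C)CCC(CN2CCN(c3ccc(C(=O)NS(=O)(=O)c4ccc(NCC5CCOCC5)c([N+](=O)[O-])c4)c(Oc4cnc5[nH]ccc5c4)c3)CC2)=C(c2ccccc2C(F)(F)F)C1`) gives 18 nM, and compound 2 (`CN1CCC(CNc2ccc(S(=O)(=O)NC(=O)c3ccc(N4CCN(CC5=C(c6ccc(C(F)(F)F)cc6)CC(C)(C)CC5)CC4)cc3Oc3cnc4[nH]ccc4c3)cc2[N+](=O)[O-])C1`) gives 8.3 nM, the lower of the two numbers, with a gap beyond the usual scatter. The unmeasured compound 3 (`CC1(C)CCC(CN2CCN(c3ccc(C(=O)NS(=O)(=O)c4ccc(OCC5CCOC5)c([N+](=O)[O-])c4)c(Oc4cnc5[nH]ccc5c4)c3)CC2)=C(c2ccc(C(F)(F)F)cc2)C1`) keeps all of compound 2 except one group: (oxolan-3-yl)methoxy in place of ((1-methylpyrrolidin-3-yl)methyl)amino on an aromatic carbon, ortho to a nitro group ((oxolan-3-yl)methoxy in place of ((1-methylpyrrolidin-3-yl)methyl)amino on an aromatic carbon). Among the measured compounds shown here, no measured pair shows this change on its own, so the expectation rests on little evidence. A modest shift toward a weaker inhibitor is expected in this assay, since compound 2 at 8.3 nM holds the lowest number seen so far. The expected step is a 2.4-fold higher number from compound 2 to compound 3 (0.38 log units; beyond the scatter). For compound 3 the estimated value is 20 nM, with an expected range from 6 nM to 70 nM.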

Compound 3, half-maximal inhibitory concentration: 47 nM
Compound 3: middle estimate off by 2.4-fold (0.37 log units), on the low side; measured number inside the range.
By their numbers in this assay, from the lowest: compound 2; then compound 1; then compound 3.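

In this assay, placing (oxolan-3-yl)methoxy in place of ((1-methylpyrrolidin-3-yl)methyl)amino on this aromatic carbon, ortho to a nitro group, gives a 5.7-fold higher number from compound 2 to compound 3 (0.75 log units; beyond the scatter) and so shows that the choice of group here matters. The two groups are close in heavy-atom count and both carry a five-membered non-aromatic ring with one hetero atom, so keeping that ring size does not preserve the number. The entering group has no hydrogen-bond donor and its ring and linking atoms are oxygen rather than nitrogen, but no measurement here explains the step. The compounds shown leave open which of these differences accounts for the step, since they all change together. An (oxolan-3-yl)methylamino group, pairing the oxygen ring with a nitrogen link, would help separate them.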